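A few compounds are considered here, and "the series" means these few. Any claim that something is new, unique, unknown or untested is made for them only; others in the source may bear on it.

Of the compounds shown here, two have been tested in a functional assay on A549 cells (Homo sapiens) for cytotoxicity, read by MTT assay, with a stated time of 24 h; a lower number here means a stronger inhibitor, a higher number a weaker inhibitor. Compound 1, `C=CC1=C(C(=O)NC(C)(C)C)C(c2ccc(OC)cc2)OC1`, returns only a limit in this assay, namely > 100000 nM. Compound 2, `C=CC1=C(C(=O)NCCC)C(c2ccc(OC)c(OC)c2)OC1`, likewise returns only a limit in this assay, > 100000 nM. On the numbers shown, compound 2 therefore stands at the floor of what the assay can report, and it is not alone there: the limit of > 100000 nM in this assay, at which 2 of the 2 values shown sit, so no ranking of the two measured compounds is possible.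

Compound 3, `C=CC1=C(C(=O)NCCC)C(c2ccc(OC)cc2)OC1`, has not yet been measured in this assay. It differs from compound 2 by hydrogen in place of methoxy on an aromatic carbon; the amide side chain and the remainder of the shared core are unchanged.

Since compound 2 offers only a limit, the size of any step to compound 3 in this assay cannot be read from the data. The expectation for compound 3 is no step beyond the scatter, with the step from compound 2 to compound 3 estimated as a step that the limit leaves unreadable from compound 2 to compound 3. Compound 3 is accordingly expected to give about 150000 nM in this assay, within a range from 50000 nM to 500000 nM, most likely again reported as a limit.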

Compound 3, half-maximal inhibitory concentration: > 100000 nM
Compound 3 ended at the assay's limit (the forecaster's own chance of this, stated with the estimate: 85%); the middle value is on the limit's open side.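

Compound 3 returns only a limit in this assay, so no step from compound 1 or compound 2 to compound 3 can be read, and the three compounds cannot be ranked: the limit of > 100000 nM in this assay, at which 3 of the 3 values shown sit.

The compounds shown leave open whether hydrogen in place of methoxy, or propyl in place of tert-butyl, changes cytotoxicity at all.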